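Series notes: amide ring exchange and volume of distribution

The compounds below may be only part of what the source reports. "The series", "measured", "known", "first", "only" and "open" are said of these compounds alone.

For the measured compounds named here, compound 1 `CCn1c(-c2cnc(C)nc2)nc2c(N[C@H]3CCN(C(=O)c4cocn4)C3)ncnc21` in an ADME assay (Rattus norvegicus, strain Wistar Han) for pharmacokinetics (on this read-out lower numbers stand for narrower distribution and higher numbers for wider distribution into tissues), gives 6.1 L/kg, the largest number recorded so far. Compound 2 `CCn1c(-c2ccc(C(F)(F)F)nc2)nc2c(O[C@H]3CCN(C(=O)c4cocn4)C3)ncnc21` gives 2.6 L/kg in this assay, a gap to compound 1 beyond the scatter. Compound 3 `CCn1c(-c2ccc(C(F)(F)F)nc2)nc2c(O[C@H]3CCN(C(=O)C4CCOC4)C3)ncnc21` gives 3.6 L/kg in this assay, which lies within the scatter of compound 1.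

Compound 4 `CCn1c(-c2cnc(C)nc2)nc2c(N[C@H]3CCN(C(=O)C4CCOCC4)C3)ncnc21` is the next member to be measured. It differs from compound 1 in one place: oxan-4-yl in place of 1,3-oxazol-4-yl on a carbonyl carbon.

Going by the values given here, one measured step bears on this change. It is a 1.4-fold higher number from compound 2 to compound 3 (0.14 log units; within the scatter), where the same leaving group was replaced on the carbonyl carbon by a saturated oxygen-containing ring, though a five-membered rather than six-membered one, and on compounds that differ from compound 1 elsewhere as well. That step stayed within the scatter. Among the compounds with values here, no measured pair shows the oxan-4-yl group itself, so the expectation rests on this single step alone and carries a broad range.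

A step of about the same small size, in the same upward direction, is expected for compound 4 in this assay, namely a 1.2-fold higher number from compound 1 to compound 4 (0.09 log units; within the scatter). Compound 4 is accordingly estimated at 7.5 L/kg in this assay, within a range of 4 L/kg to 14 L/kg.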

Compound 4, volume of distribution: 4.3 L/kg
Compound 4: the middle estimate sits 1.7-fold (0.24 log units) above what was measured, within the range that was stated.
By their numbers in this assay, from the lowest: compounds 2, 3, 4 and 1 (each within the scatter of the next, the first and the last beyond it).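

For the compounds shown here, the exchange of 1,3-oxazol-4-yl for oxan-4-yl on a carbonyl carbon whose other neighbour is an amide-type nitrogen in a ring gives the first direct reading for this six-membered non-aromatic ring: a 1.4-fold lower number from compound 1 to compound 4 (0.15 log units; within the scatter). Read beside a 1.4-fold higher number from compound 2 to compound 3 (0.14 log units; within the scatter), it means that in both listed pairs a non-aromatic oxygen-bearing ring in place of 1,3-oxazol-4-yl stays within the scatter in this assay, on two different remainders of the molecule and with two ring sizes, and neither pair goes against this. Within these two pairs, then, the read-out does not separate the aromatic ring from the non-aromatic ones at this position, and no available evidence gives a reason for either step.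

As far as these compounds go, whether this tolerance reaches beyond oxygen-bearing rings remains open: a basic amine such as piperidin-4-yl, a carboxylic acid, or an open chain such as methoxyethyl on the same carbonyl carbon could still give a step beyond the scatter. Also open, from the compounds shown here alone, is whether oxan-4-yl gives a step of similar size on the remainder of compound 2.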